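Aryl substituent changes on the shared core: compound 4

The source may hold more compounds than are shown below. What is called first, only, known or untested is meant among the compounds shown, and "the series" means these compounds.

Measured in a functional assay on SK-MEL-5 cells (Homo sapiens) for inhibition, read by sulforhodamine B assay, with a stated time of 48 h, tested at 10 uM; on this read-out lower numbers stand for less inhibition and higher numbers for more inhibition at the one concentration tested (going by the name of the read-out):
compound 1 `COc1ccc(-c2cn3ccnc3c(-c3ccc4ncn(C5CCCCC5)c4c3)n2)cc1` — 92.3%
compound 2 `c1cn2cc(-c3ccsc3)nc(-c3ccc4ncn(C5CCCCC5)c4c3)c2n1` — 25%
compound 3 `Clc1ccc(-c2cn3ccnc3c(-c3ccc4ncn(C5CCCCC5)c4c3)n2)cc1` — 12.4%

Compound 3 stands lowest of the three numbers in this assay. Its nearest neighbour is compound 2, the step being a number 12.6 percentage points lower from compound 2 to compound 3 (beyond the scatter). The widest gap is to compound 1, with a number 79.9 percentage points lower from compound 1 to compound 3 (beyond the scatter), so exchanging methoxy for chloro on the pendant phenyl gives the largest drop in the number seen so far. The step of a number 67.3 percentage points lower from compound 1 to compound 2 (beyond the scatter) shows that the pendant aryl group itself also carries a large effect.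

Compound 4 `Fc1ccccc1-c1cn2ccnc2c(-c2ccc3ncn(C4CCCCC4)c3c2)n1` is not yet measured. It differs from compound 3 by 2-fluorophenyl in place of 4-chlorophenyl on an aromatic carbon. For the measured compounds named here, no measured step exchanges one halogen for another, nor moves a substituent around the phenyl ring, so the measured steps bear on this change only indirectly: they show the pendant aryl group can swing the read-out widely, while compound 3 already sits at the bottom of the present range. A modest upward step or none beyond the scatter is expected in this assay.

Compound 4 is estimated to give 22%, with a range of 5% to 50%, meaning an expected step of a number 9.6 percentage points higher from compound 3 to compound 4 (within the scatter).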

Compound 4, a percentage reported as inhibition, at one concentration (the size of the read-out at that concentration, not a potency): 6.5%
Estimate against measurement, compound 4: 15.5 percentage points above; the range from low to high includes it.
By their numbers in this assay, from the lowest: compounds 4 and 3 (each within the scatter of the next); then compound 2; then compound 1.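

In this assay the exchange of 4-chlorophenyl for 2-fluorophenyl gives a number 5.9 percentage points lower from compound 3 to compound 4 (within the scatter), so a phenyl group carrying a different halogen at a different ring place reads the same as compound 3 within the scatter. The steps of a number 18.5 percentage points lower from compound 2 to compound 4 (beyond the scatter) and a number 85.8 percentage points lower from compound 1 to compound 4 (beyond the scatter) place compound 4 with compound 3 at the low end of the series: of the four aryl groups at this position, only the 4-methoxyphenyl of compound 1 gives a high number, while the two halogen-bearing phenyl groups and the thiophen-3-yl of compound 2 all stand far lower. No measured information on hand accounts for these differences.

Compounds 3 and 4 change the halogen and its ring place together, so the effect of each alone remains unresolved, as does whether the high number of compound 1 depends on the methoxy group itself or on where it sits on the phenyl ring. Also open, on these data alone, is how a phenyl group bearing an ethoxy group, an amine or a carboxylic acid would read out, and how these single-concentration numbers would translate into potency.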